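A pyrimidin-2-yl in place of 4-fluorophenyl

The compounds below may be only part of what the source reports. "The series", "measured", "known", "first", "only" and "open" are said of these compounds alone.

In a toxicity assay on HepG2 2.2.15 cells (Homo sapiens) for cytotoxicity, read by CellTiter-Glo (a lower number here means that less compound is tolerated, a higher number that more compound is tolerated), compound 1 `O=C1OC(c2ccccc2)CN1c1cnn2c1CN(C(=O)Nc1cc(F)c(F)c(F)c1)C(C1CC1)C2` gives 7410 nM as its reading, and compound 2 `O=C1CC(c2ccc(F)cc2)CN1c1cnn2c1CN(C(=O)Nc1cc(F)c(F)c(F)c1)C(C1CC1)C2` gives 32100 nM as its reading. Compound 2 therefore stands highest of the two measured compounds, and its gap to compound 1 lies beyond the usual scatter. These two compounds differ in more than one place, so neither offers a clean single-change comparison. Compound 3 `O=C1CC(c2ncccn2)CN1c1cnn2c1CN(C(=O)Nc1cc(F)c(F)c(F)c1)C(C1CC1)C2` carries pyrimidin-2-yl in place of 4-fluorophenyl on a saturated ring carbon and otherwise matches compound 2. For the measured compounds named here, no measured step shows what this exchange does in this assay and only a small upward move is expected, one that may stay within the scatter. The expected change is estimated as a 1.3-fold higher number from compound 2 to compound 3 (0.12 log units; within the scatter) on this reading. For compound 3 the estimated value is 42000 nM with an expected range from 15000 nM to 100000 nM in this assay.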

Compound 3, half-maximal cytotoxic concentration: > 200000 nM
Compound 3: a limit, no number; the forecaster's own chance of this, stated with the estimate: 35%; at least 4.7-fold (0.67 log units) between middle value and limit.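

In this assay, for the compounds shown here, pyrimidin-2-yl in place of 4-fluorophenyl on a saturated ring carbon gives an at least 6.2-fold higher number from compound 2 to compound 3 (0.79 log units; beyond the scatter), the first single-place evidence that this position bears on how much compound is tolerated. The wider exchange, 2-oxo-4-(pyrimidin-2-yl)pyrrolidin-1-yl in place of 2-oxo-5-phenyl-1,3-oxazolidin-3-yl on an aromatic carbon, gives an at least 26-fold higher number from compound 1 to compound 3 (1.43 log units; beyond the scatter). The reading of compound 3 is a limit and not a number, so both steps are minimum sizes only: the limit of > 200000 nM in this assay, at which 1 of the 3 values shown sits.

The compounds shown leave open how far compound 3 lies beyond that limit, and whether the step follows the ring nitrogens or the loss of the fluorine. A pyridin-2-yl or an unsubstituted phenyl on the same saturated ring carbon would separate these two changes.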